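A few compounds are considered here, and "the series" means these few. Any claim that something is new, unique, unknown or untested is made for them only; others in the source may bear on it.

Working notes on the series.

Compound 1 `CC1Cc2c(sc(NC(=O)c3ccccc3O)c2C(N)=O)C(C)O1` and compound 2 `CC1(C)Cc2c(sc(NC(=O)c3ccn[nH]3)c2C(N)=O)C(C)(C)O1` share one core and differ in the acyl part on the amide nitrogen. In an assay on cells for positive allosteric modulation of Cystic fibrosis transmembrane conductance regulator variant F508del (Homo sapiens), with stated times of 10 min and 7 s, in the presence of a further agent that is not named here (on this read-out lower numbers stand for an effect already at smaller amounts and higher numbers for an effect only at larger amounts of compound), compound 1 gives 4 nM, and in this assay compound 2 gives 3 nM. Compound 2 thus stands at the lower of the two numbers, but compound 1 lies within the scatter of it, so no order between the two can be read from these values.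

Compound 3 `CC1(C)Cc2c(sc(NC(=O)[C@@H](O)C(C)(C)C)c2C(N)=O)C(C)(C)O1` has not been measured. The change from compound 2 is 1-hydroxy-2,2-dimethylpropyl in place of 1H-pyrazol-5-yl on a carbonyl carbon; an aromatic ring bearing a donor gives way to an open chain that keeps one donor and one acceptor. Among the measured compounds shown here, no measured pair in the set shows a change of this kind, so no step size is known from the data.

For compound 3 a shift towards higher numbers in this assay is expected, of moderate size, in the range a 4.0-fold higher number from compound 2 to compound 3 (0.60 log units; beyond the scatter). The expected value for compound 3 is 12 nM, estimated to lie between 3 nM and 60 nM.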

Compound 3, half-maximal effective concentration: 2.7 nM
Compound 3: middle estimate off by 4.4-fold (0.65 log units), on the high side; the whole stated range lies above it.
By their numbers in this assay, from the lowest: compounds 3, 2 and 1 (each within the scatter of the next).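

In this assay, putting 1-hydroxy-2,2-dimethylpropyl in place of 1H-pyrazol-5-yl on a carbonyl carbon gives a 1.1-fold lower number from compound 2 to compound 3 (0.05 log units; within the scatter), so for this pair the five-membered aromatic ring is not needed to keep a value in this range, and an open chain with one defined stereocentre does as well. Among the compounds shown here, this is the first step that can be read at this position, and it shows that the two groups, which have the same count of hydrogen-bond donors and acceptors but different shapes and atoms, cannot be told apart on this read-out. Nothing at hand explains why these two groups give matching values.

Open is whether the hydroxy group of compound 3 matters at all, as the compounds shown do not tell how a plain 2,2-dimethylpropyl or a chain carrying an amine or a carboxylic acid in its place would read in this assay. Also open, from the compounds shown here alone, is how the opposite configuration at the stereocentre of compound 3 would compare.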